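Swapping the Cyano for Chloro on the Biaryl Tail

The compounds below may be only part of what the source reports. "The series", "measured", "known", "first", "only" and "open" are said of these compounds alone.

Compound 1, `CC(C)C[C@H](N)CN(C(=O)[C@@H]1C[C@H]1c1ccccc1)c1ccc(-c2ccncc2)cc1`: 13000 nM in a functional assay for agonist activity at G protein-coupled receptor 88 (Homo sapiens), read by HTRF and cAMP accumulation; on this read-out lower numbers stand for an effect already at smaller amounts and higher numbers for an effect only at larger amounts of compound
Compound 2, `CC(C)C[C@H](N)CN(C(=O)[C@@H]1C[C@H]1c1ccccc1)c1ccc(-c2ccc(F)cc2)cc1`: 900 nM in this assay
Compound 3, `CC(C)C[C@H](N)CN(C(=O)[C@@H]1C[C@H]1c1ccccc1)c1ccc(-c2ccc(C#N)cc2)cc1`: 670 nM in this assay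

Compound 3 has the lowest number of the three, but its gap to compound 2 is within the scatter; only compound 1 sits clearly apart. Compound 4, `CC(C)C[C@H](N)CN(C(=O)[C@@H]1C[C@H]1c1ccccc1)c1ccc(-c2ccc(Cl)cc2)cc1`, differs from compound 3 by chloro in place of cyano on an aromatic carbon. The large steps of a 14-fold lower number from compound 1 to compound 2 (1.16 log units; beyond the scatter) and a 19-fold lower number from compound 1 to compound 3 (1.29 log units; beyond the scatter) concern a different exchange on the same ring and do not bear directly on this change. Within the data shown here, the only step that does is a 1.3-fold lower number from compound 2 to compound 3 (0.13 log units; within the scatter), which stayed within the scatter, so the tail at this position tolerated two different small substituents without a clear difference. The expectation for compound 4 is therefore a step of a 1.1-fold higher number from compound 3 to compound 4 (0.05 log units; within the scatter) in this assay, nothing beyond the scatter. Compound 4 is estimated at 750 nM, with a range from 300 nM to 1900 nM.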

Compound 4, half-maximal effective concentration: 640 nM
Beside the measured number, compound 4's estimate is 1.2-fold (0.07 log units) above it, within the range that was stated.
By their numbers in this assay, from the lowest: compounds 4, 3 and 2 (each within the scatter of the next); then compound 1.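

Chloro in place of cyano on this aromatic carbon makes no clear difference in this assay (a 1.0-fold lower number from compound 3 to compound 4 (0.02 log units; within the scatter)), and neither does chloro in place of fluoro (a 1.4-fold lower number from compound 2 to compound 4 (0.15 log units; within the scatter)), so three different small substituents now read alike here. The 4-chlorophenyl tail also stands clearly apart from pyridin-4-yl (a 20-fold lower number from compound 1 to compound 4 (1.31 log units; beyond the scatter)), as the 4-fluorophenyl and 4-cyanophenyl tails do. Nothing available explains why these substituents read alike.

Still open, from the compounds shown here alone, is whether an amine or a carboxylic acid on this same carbon would keep the number. A longer chain there is equally untested by the compounds shown.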